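The source may hold more compounds than are shown below. What is called first, only, known or untested is meant among the compounds shown, and "the series" means these compounds.

Compound 1 `CCCCOc1ccccc1Cc1cnc(N)nc1N` stands as the lower of the two numbers in an assay for inhibition of Dihydrofolate reductase (Gallus gallus) (on this read-out lower numbers stand for stronger inhibition and higher numbers for weaker inhibition), where compound 1 gives 8710 nM. Its nearest neighbour is compound 2 `Nc1ncc(Cc2ccccc2O)c(N)n1`, which in this assay gives 89100 nM; the change between them, hydrogen in place of butyl on an oxygen on an aromatic ring, brought a 10-fold higher number from compound 1 to compound 2 (1.01 log units; beyond the scatter). Compound 3 `NC(=O)COc1ccccc1Cc1cnc(N)nc1N` keeps the shared core of compound 1 and alters the chain at the oxygen: carbamoyl in place of propyl on a saturated chain carbon bound to an oxygen on an aromatic ring. Among the measured compounds shown here, no measured step shows exactly this change. The step from compound 1 to compound 2, in which the whole butyl group gave way to hydrogen, is the only one that bears on it, and it was large. Shortening the chain while adding a carbamoyl is expected to undo part of that loss but not all of it, so a weakening step a 3.4-fold higher number from compound 1 to compound 3 (0.54 log units; beyond the scatter) is expected. Compound 3 is therefore estimated at 30000 nM in this assay, with a range from 8000 nM to 110000 nM.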

Compound 3, inhibition constant: 33900 nM
Estimate against measurement, compound 3: 1.1-fold (0.05 log units) below; low and high end bracket the measured number.
By their numbers in this assay, from the lowest: compound 1; then compound 3; then compound 2.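

Compound 3 shows that the oxygen on the aromatic ring need not carry a plain carbon chain to do better than hydrogen: in this assay, carbamoylmethyl in place of that hydrogen gives a real gain in inhibition (a 2.6-fold lower number from compound 2 to compound 3 (0.42 log units; beyond the scatter)). The gain is only partial, since carbamoyl in place of propyl still weakens inhibition (a 3.9-fold higher number from compound 1 to compound 3 (0.59 log units; beyond the scatter)). Both steps are modest and beyond the scatter, so compound 3 sits between the two earlier compounds, and compound 1, with its butyl group, remains the strongest of the three.

As far as these compounds go, it stays open how an amine or a carboxylic acid in place of carbamoyl, or a longer chain in place of butyl, would compare. Nothing at hand says what lies behind the difference between butyl and carbamoylmethyl at this oxygen.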